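The source may report more compounds than this note shows. Statements on the series, on what has been measured and on what is new or still open speak of the compounds shown alone.

The series keeps a shared core and varies the substituent on the ring amine nitrogen and the group on the saturated ring carbon. Among the measured compounds shown here, in an assay on Sf9 cells for inhibition of histone deacetylase 11 (Homo sapiens), read by fluorescence, tested at 0.5 uM (on this read-out lower numbers stand for less inhibition and higher numbers for more inhibition at the one concentration tested (going by the name of the read-out)), compound 3 `O=C(NO)c1ccc(-c2cn([C@@H]3C[C@H](CO)N(CCCc4ccccc4)C3)nn2)cc1` gives 15%, the only number recorded. The other two entries are limits of the assay. Compound 2 `O=C(NO)c1ccc(-c2cn([C@@H]3C[C@H](C(=O)O)N(CCCc4ccccc4)C3)nn2)cc1` sits at the limit < 10%. Compound 1 `O=C(NO)c1ccc(-c2cn([C@@H]3C[C@@H](CO)N(Cc4ccccc4)C3)nn2)cc1` also sits at the limit < 10%. For the measured compounds named here, compound 1 and compound 4 differ only in stereochemistry, and no step between them is recorded. Going by the values given here, the one measured step, a number at least 5 percentage points higher from compound 2 to compound 3 (that floor lies within the scatter), exchanges carboxy for hydroxymethyl on a saturated ring carbon and lies within the scatter; it does not touch the group on the amine nitrogen.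

The step to compound 4 `O=C(NO)c1ccc(-c2cn([C@@H]3C[C@H](CO)N(Cc4ccccc4)C3)nn2)cc1` is phenyl in place of phenethyl on a saturated chain carbon bound to an amine nitrogen in a ring. Among the compounds with values here, no measured step bears on this particular change, so there is no basis for expecting a shift in either direction. Compound 3 itself sits close to the limit where two of the three values rest (the limit of < 10% in this assay, at which 2 of the 3 values shown sit). The estimated step of a number 5 percentage points lower from compound 3 to compound 4 (within the scatter) is therefore expected to stay within the scatter. Compound 4 is expected to give about 10% in this assay, within a range of 3% to 20%, with a fair chance that only a limit is reported.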

Compound 4, a percentage reported as inhibition, at one concentration (the size of the read-out at that concentration, not a potency): 14%
Beside the measured number, compound 4's estimate is 4 percentage points below it, and the stated range covers the measured number.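

The exchange of phenethyl for phenyl on a saturated chain carbon bound to an amine nitrogen in a ring gives a number 1 percentage points lower from compound 3 to compound 4 (within the scatter), so in this assay the 3-phenylpropyl and benzyl groups cannot be told apart at this place, at least with hydroxymethyl on the saturated ring carbon in this configuration. Compound 1 gives < 10%, which is a limit of the assay. The configuration at the saturated ring carbon can now be compared for the first time, and with a number at least 4 percentage points higher from compound 1 to compound 4 (that floor lies within the scatter) the pair neither establishes nor excludes an effect of the stereocentre, a reading that rests on one limit and on a single clean contrast: the fact that compounds 1 and 4 differ only in the configuration as drawn

Going by these compounds, it remains open whether any group on the ring amine nitrogen or the saturated ring carbon would carry this read-out clear of the floor where the series gathers: the limit of < 10% in this assay, at which 2 of the 4 values shown sit A longer chain or a pyridylmethyl group on the amine nitrogen, and a primary amide or an aminomethyl group on the saturated ring carbon, would test this, as would the carboxylic acid with the benzyl group.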